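Replacing the methyl of compound 3 with oxolan-3-yl

A few compounds are considered here, and "the series" means these few. Any claim that something is new, unique, unknown or untested is made for them only; others in the source may bear on it.

Going by the values given here, in an in vitro ADME assay on microsomes from liver (Homo sapiens) for pharmacokinetics (a lower number here means slower removal, a higher number faster removal of the compound), compound 3 (`CC(=O)N[C@@H](CCN1C[C@@H]2CN(C(=O)c3ccc(C(F)(F)F)cn3)C[C@@H]2C1)c1cccc(F)c1`) gives 152 mL.min-1.g-1, the middle of the three numbers known so far. Compound 1 (`O=C(N[C@@H](CCN1C[C@@H]2CN(C(=O)c3cccc(F)c3)C[C@@H]2C1)c1cccc(F)c1)C1CCOC1`) stands higher at 331 mL.min-1.g-1, and compound 2 (`O=C(N[C@@H](CCN1C[C@@H]2CN(C(=O)c3ccccn3)C[C@@H]2C1)c1cccc(F)c1)C1CCOC1`) stands lower at 55 mL.min-1.g-1. Compound 4 (`O=C(N[C@@H](CCN1C[C@@H]2CN(C(=O)c3ccc(C(F)(F)F)cn3)C[C@@H]2C1)c1cccc(F)c1)C1CCOC1`) differs from compound 3 by oxolan-3-yl in place of methyl on a carbonyl carbon, with oxolan-3-yl in place of methyl on a carbonyl carbon. Among the compounds with values here, the only measured step, a 6.0-fold lower number from compound 1 to compound 2 (0.78 log units; beyond the scatter), is modest but concerns a different change, pyridin-2-yl in place of 3-fluorophenyl, so it bears on this one only indirectly. Within the data shown here, no measured step tests the new change directly, so only a small upward move is expected, a 1.3-fold higher number from compound 3 to compound 4 (0.10 log units; within the scatter). Compound 4 is estimated at 190 mL.min-1.g-1, with an expected range of 85 mL.min-1.g-1 to 420 mL.min-1.g-1.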

Compound 4, intrinsic clearance in microsomes: 343 mL.min-1.g-1
Compound 4: middle estimate off by 1.8-fold (0.26 log units), on the low side; the range from low to high includes it.
By their numbers in this assay, from the lowest: compound 2; then compound 3; then compounds 1 and 4 (each within the scatter of the next).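

In this assay, the carbonyl carbon whose other neighbour is an amide-type nitrogen proves sensitive to this change, with oxolan-3-yl in place of methyl giving a 2.3-fold higher number from compound 3 to compound 4 (0.35 log units; beyond the scatter) in the series carrying 5-(trifluoromethyl)pyridin-2-yl. With oxolan-3-yl held constant, trifluoromethyl in place of hydrogen on an aromatic carbon gives a 6.2-fold higher number from compound 2 to compound 4 (0.79 log units; beyond the scatter) and 5-(trifluoromethyl)pyridin-2-yl in place of 3-fluorophenyl gives a 1.0-fold higher number from compound 1 to compound 4 (0.02 log units; within the scatter) as a further comparison. Nothing available explains these steps. Still open, going by these compounds, is how an amine or a longer chain would behave on that carbonyl carbon, and whether the step from methyl to oxolan-3-yl has the same size with pyridin-2-yl or 3-fluorophenyl on the other carbonyl.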